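The source may report more compounds than this note shows. Statements on the series, on what has been measured and on what is new or still open speak of the compounds shown alone.

Working notes on the series. In an ADME assay on J774 cells (Mus musculus) for antiproliferative activity, with a stated time of 72 h (a lower number here means that less compound is needed, a higher number that more compound is needed for the effect), compound 1 `CCCCc1cc2c(=O)c(-c3ccccc3)c(C)[nH]c2cc1OCCOc1ccccc1` gives 23000 nM while compound 2 `CCCCc1cc2c(=O)c(-c3ccncc3)c(C)[nH]c2cc1OCCOc1ccccc1` gives 23000 nM and compound 3 `CCCCc1cc2c(=O)c(-c3cccnc3)c(C)[nH]c2cc1OCCOc1ccccc1` gives 23000 nM on the same read-out. Compound 3 therefore stands level with the other two, and no order can be drawn among them.

The next structure is compound 4 `CCCCc1cc2c(=O)c(-c3ccc(C(F)(F)F)cc3)c(C)[nH]c2cc1OCCOc1ccccc1`, which has 4-(trifluoromethyl)phenyl in place of pyridin-3-yl on an aromatic carbon of the shared core. The counted difference is 4-(trifluoromethyl)phenyl in place of pyridin-3-yl on an aromatic carbon and it falls at the same place as all the measured changes.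

For the measured compounds named here, three measured steps bear on this place: no change at the digits printed from compound 1 to compound 2 (within the scatter) for pyridin-4-yl in place of phenyl, no change at the digits printed from compound 1 to compound 3 (within the scatter) for pyridin-3-yl in place of phenyl, and no change at the digits printed from compound 2 to compound 3 (within the scatter) for pyridin-3-yl in place of pyridin-4-yl. None of them was larger than the scatter. Going by the values given here, they cover only unsubstituted rings, however, and no measured compound carries trifluoromethyl, so the reading across is uncertain.

On these steps, no shift beyond the scatter is expected in this assay in either direction. The expected size is a 1.2-fold lower number from compound 3 to compound 4 (0.06 log units; within the scatter) and this is an estimate only. For compound 4 the estimated value is 20000 nM with an expected range of 8000 nM to 40000 nM for now.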

Compound 4, half-maximal effective concentration: 20000 nM
Compound 4: the middle estimate sits on the measured number at the digits printed, within the range that was stated.
By their numbers in this assay, from the lowest: compounds 4, 1, 2 and 3 (each within the scatter of the next).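

In this assay, for the compounds shown here, the earlier compounds spoke only for unsubstituted rings at this place, and compound 4 extends the reading to a ring that carries a substituent: trifluoromethyl in place of hydrogen on the phenyl ring gives a 1.2-fold lower number from compound 1 to compound 4 (0.06 log units; within the scatter). Set against the two pyridines, where the ring nitrogen leaves and trifluoromethyl enters in a single step, the result is a 1.2-fold lower number from compound 2 to compound 4 (0.06 log units; within the scatter) and a 1.2-fold lower number from compound 3 to compound 4 (0.06 log units; within the scatter), so among these four compounds neither the ring nitrogen nor the trifluoromethyl group separates one compound from another in this assay. The data on hand offer no explanation for this flat reading.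

Still open, as far as these compounds go, is whether an amine or a carboxylic acid on this ring, or a saturated ring in its place, would move the number beyond the scatter. Also open, from the compounds shown here alone, is whether this place is simply less telling than the rest of the shared core, for instance whether a longer chain in place of the butyl chain would shift the value where these ring swaps do not.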